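Swapping the hydroxynaphthyl of compound 2 for a dichlorophenyl

A few compounds are considered here, and "the series" means these few. Any claim that something is new, unique, unknown or untested is made for them only; others in the source may bear on it.

For the measured compounds named here, compound 2 `CN(C)CCn1cnnc1-c1cc(Oc2ccc(NC(=O)N/N=C/c3c(O)ccc4ccccc34)cc2F)ccn1` holds the lowest of the two numbers measured so far: in a functional assay on NCI-H460 cells (Homo sapiens) for cytotoxicity, read by MTT assay, with a stated time of 72 h (on this read-out higher numbers stand for weaker inhibition and lower numbers for stronger inhibition), compound 2 gives 890 nM, whereas compound 1 `CN(C)CCn1cnnc1-c1cc(Oc2ccc(NC(=O)N/N=C/c3ccc(O)c(O)c3)cc2F)ccn1` gives 1930 nM, the step being a 2.2-fold lower number from compound 1 to compound 2 (0.34 log units; beyond the scatter). Compound 3 `CN(C)CCn1cnnc1-c1cc(Oc2ccc(NC(=O)N/N=C/c3ccc(Cl)cc3Cl)cc2F)ccn1` differs from compound 2 by 2,4-dichlorophenyl in place of 2-hydroxynaphthalen-1-yl on a carbon with a double bond to nitrogen. Going by the values given here, no measured step covers trading a hydroxylated ring for a chlorinated one; the single step seen only shows that changing this ring moves the number modestly. A small weakening is therefore expected, a 1.7-fold higher number from compound 2 to compound 3 (0.23 log units; within the scatter). Compound 3 is estimated to give 1500 nM in this assay, plausibly between 500 nM and 4500 nM.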

Compound 3, half-maximal inhibitory concentration: 130 nM
The estimate for compound 3 lay 12-fold (1.06 log units) above the measured number; measured number below the stated range.
By their numbers in this assay, from the lowest: compound 3; then compound 2; then compound 1.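

In this assay, putting 2,4-dichlorophenyl on this carbon gives a 6.8-fold lower number from compound 2 to compound 3 (0.84 log units; beyond the scatter) and a 15-fold lower number from compound 1 to compound 3 (1.17 log units; beyond the scatter), so a ring without hydroxyl groups gives the lowest number of the three. This ring can therefore move the number much further than the first step showed, and no hydroxyl group on it is needed for a low number. Nothing available explains why the chlorinated ring does better. From the compounds shown here alone, whether both chlorines are needed stays open, as does how a phenyl ring carrying one chlorine, a methoxy group or a nitrile would behave here.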